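Bromo for methyl, repeated on a diol pair

The source may report more compounds than this note shows. Statements on the series, on what has been measured and on what is new or still open speak of the compounds shown alone.

Compound 1 `Cc1ccc(/C=C/c2ncc([N+](=O)[O-])n2C)cc1` bears a methyl on its phenyl ring. In an ADME assay on HeLa cells (Homo sapiens) for cytotoxicity, read by resazurin assay, with a stated time of 2 days (a higher number here means a weaker inhibitor, a lower number a stronger inhibitor), compound 1 reaches only the limit of the assay, > 100000 nM. Compound 2 `Cn1c([N+](=O)[O-])cnc1/C=C/c1ccc(Br)cc1` is the bromo counterpart, and in this assay compound 2 gives 72400 nM. The step of an at least 1.3-fold lower number from compound 1 to compound 2 (0.14 log units; that floor lies within the scatter) comes from the change (bromo in place of methyl on an aromatic carbon).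

Compound 3 `Cc1ccc(C(O)C(O)c2ncc([N+](=O)[O-])n2C)cc1` carries the same methylphenyl on a different core. In this assay compound 3 also stops at the limit, > 100000 nM. How the core of compound 3 differs from the core of compound 1 is not broken down here. Compound 4 `Cn1c([N+](=O)[O-])cnc1C(O)C(O)c1ccc(Br)cc1` has not been measured; it differs from compound 3 by bromo in place of methyl on an aromatic carbon, the same change as from compound 1 to compound 2, at a place described in the same words.

Two of the three values sit at the limit of > 100000 nM in this assay, at which 2 of the 3 values shown sit, so the earlier step is known only as a floor that lies within the scatter, and the direction of the bromo change is not settled. For compound 4 the expected step of a number no higher from compound 3 to compound 4 (the limit leaves the size open) is set beside the earlier one as a small move of uncertain sign. That rests on compound 2, which in this assay gives 72400 nM, a high number. Compound 4 is therefore estimated at 100000 nM, between 40000 nM and 300000 nM, with a fair chance that the reading again stops at the limit.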

Compound 4, half-maximal inhibitory concentration: 91200 nM
Beside the measured number, compound 4's estimate is 1.1-fold (0.04 log units) above it, within the range that was stated.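

Carried to the core of compound 3, bromo in place of methyl gives an at least 1.0-fold lower number from compound 3 to compound 4 (0.04 log units; that floor lies within the scatter) in this assay, and set beside the same change on the core of compound 1 the result reads: the same change on two cores in this assay, an at least 1.3-fold lower number (0.14 log units; that floor lies within the scatter) from compound 1 to compound 2 and an at least 1.0-fold lower number (0.04 log units; that floor lies within the scatter) from compound 3 to compound 4; the limit leaves it open whether they differ.
The two pairs look alike in form, with the methyl compound stopping at a limit of the assay and the bromo compound giving a number, yet each step is only a floor within the scatter, so neither a direction nor a size for the change is fixed on either core.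
The series therefore shows nothing against the change carrying over from one core to the other, but it does not show that it carries over, and the readings crowd the top of the range: the limit of > 100000 nM in this assay, at which 2 of the 4 values shown sit.

Still open, on these data alone, is whether any other group in place of the methyl on the phenyl ring, such as an amine, a carboxylic acid or a longer chain, gives a number well clear of the limit in this assay. Also open, as far as these compounds go, is whether a pair with both members clear of the limit would let the bromo for methyl change be sized on these two cores at all.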